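Removing a Methyl from the Aromatic Oxygen of Compound 3

The source may hold more compounds than are shown below. What is called first, only, known or untested is meant among the compounds shown, and "the series" means these compounds.

Compound 1 `COc1cc(C)cc(-c2c(-c3ccnc(-c4ccc(C(C)=O)cc4)c3)cnn2CC#N)c1`: 3590 nM
Compound 2 `Cc1cc(O)cc(-c2nn(CC#N)cc2-c2ccnc(-c3ccc(Oc4ccccc4)cc3)c2)c1`: 2150 nM
Compound 3 `COc1cc(C)cc(-c2nn(CC#N)cc2-c2ccnc(-c3ccc(N(C)C)cc3)c2)c1`: 363 nM

In a functional assay on PC-3 cells (Homo sapiens) for inhibition, read by sulforhodamine B assay, with a stated time of 48 h (a higher number here means a weaker inhibitor of growth, a lower number a stronger inhibitor of growth), compound 3 gives the lowest number of the three; compound 2 stands well beyond the scatter above it, and compound 1 further still. Compound 4 `Cc1cc(O)cc(-c2nn(CC#N)cc2-c2ccnc(-c3ccc(N(C)C)cc3)c2)c1` differs from compound 3 in one place only, on an oxygen on an aromatic ring: hydrogen in place of methyl on an oxygen on an aromatic ring. Compound 1 carries a methoxy group and compound 2 a hydroxy group as well, but the two also differ elsewhere, so their values say nothing clean about this single change. The step is therefore expected to be small, possibly none beyond the scatter, with at most a slight drift toward a higher number: a 1.4-fold higher number from compound 3 to compound 4 (0.14 log units; within the scatter). Compound 4 is estimated at 500 nM, with a likely range from 200 nM to 1500 nM.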

Compound 4, concentration for 50% growth inhibition: 3770 nM
Estimate against measurement, compound 4: 7.5-fold (0.88 log units) below; the whole stated range lies below it.
By their numbers in this assay, from the lowest: compound 3; then compounds 2, 1 and 4 (each within the scatter of the next).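

In this assay the methoxy group proves to matter at this place: hydrogen in place of its methyl gives a 10-fold higher number from compound 3 to compound 4 (1.02 log units; beyond the scatter), a large step from the loss of a single carbon. With the hydroxy group present, dimethylamino in place of phenoxy gives a 1.8-fold higher number from compound 2 to compound 4 (0.24 log units; within the scatter), so that swap shows no clear change. Nothing available explains the large step. As far as these compounds go, how an ethoxy group or a fluorine atom would read at this place remains open, as does whether the phenoxy compounds respond to methoxy and hydroxy in the same way.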